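Amine substituent variation on the quinone core: compound 3

The source may hold more compounds than are shown below. What is called first, only, known or untested is meant among the compounds shown, and "the series" means these compounds.

Measured so far:
Compound 1, `CNC1=CC(=O)c2ccccc2C1=O`: 55700 nM
Compound 2, `O=C1C=C(N2CCCC2)C(=O)c2ccccc21`: 159000 nM

In a functional assay on HCT-116 cells (Homo sapiens) for antiproliferative activity, read by MTT assay (on this read-out lower numbers stand for stronger inhibition and higher numbers for weaker inhibition), compound 1 stands lowest of the two numbers; its nearest neighbour is compound 2, reached by a 2.9-fold higher number from compound 1 to compound 2 (0.46 log units; beyond the scatter), a modest rise. Compound 3, `O=C1C=C(NCc2ccccc2)C(=O)c2ccccc21`, differs from compound 1 by phenyl in place of hydrogen on a saturated chain carbon bound to an amine nitrogen. Among the compounds with values here, the only measured step bearing on this region of the structure is a 2.9-fold higher number from compound 1 to compound 2 (0.46 log units; beyond the scatter), which altered the amine itself rather than the saturated chain carbon bound to it; no measured step adds a phenyl on that carbon. The measured step is therefore a weak guide, and it gives no reason to expect a large move in either direction. A step of a 1.2-fold lower number from compound 1 to compound 3 (0.09 log units; within the scatter) is expected, within or near the scatter. Compound 3 is accordingly estimated at 45000 nM, with a range from 12000 nM to 160000 nM.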

Compound 3, half-maximal inhibitory concentration: 130000 nM
Compound 3: middle estimate off by 2.9-fold (0.46 log units), on the low side, within the range that was stated.
By their numbers in this assay, from the lowest: compound 1; then compounds 3 and 2 (each within the scatter of the next).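

In this assay, phenyl in place of hydrogen on a saturated chain carbon bound to an amine nitrogen gives a 2.3-fold higher number from compound 1 to compound 3 (0.37 log units; beyond the scatter) and so brings no gain at this position. Read with a 2.9-fold higher number from compound 1 to compound 2 (0.46 log units; beyond the scatter) as the earlier change, it shows that both departures from the methylamino group of compound 1, one replacing the amine and one adding phenyl on its chain carbon, raise the number beyond the scatter. Nothing available accounts for this rise.

From the compounds shown here alone, whether the rise belongs to phenyl itself or to any larger group on this carbon remains open, and an ethyl or a longer alkyl chain on the amine nitrogen would help to separate the two. A pyridyl ring in place of phenyl, or a hydroxyl or carboxylic acid on the chain, is also untested among the compounds shown here.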